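The compounds below may be only part of what the source reports. "The series", "measured", "known", "first", "only" and "open" are said of these compounds alone.

Going by the values given here, in a functional assay on HCT-116 cells (Homo sapiens) for inhibition, read by MTT assay, with a stated time of 48 h (on this read-out lower numbers stand for stronger inhibition and higher numbers for weaker inhibition), compound 1 `COc1ccc(CN(C(=O)C=C(C)C)c2cc(OC)c(OC)c(OC)c2)cc1O` gives 290 nM, the lower of the two numbers so far. Compound 2 `C/C=C/C(=O)N(Cc1cc(OC)c(OC)c(OC)c1)c1ccc(OC)c(O)c1` gives 8450 nM, a gap beyond the usual scatter. Compound 3 `COc1ccc(CN(C(=O)CCl)c2cc(OC)c(OC)c(OC)c2)cc1O` keeps the core of compound 1 but has chloromethyl in place of 2-methylprop-1-en-1-yl on a carbonyl carbon. Among the compounds with values here, no measured pair isolates this change, so any forecast is uncertain. A moderately weaker result is expected, with an estimated move a 2.4-fold higher number from compound 1 to compound 3 (0.38 log units; beyond the scatter). In this assay, the estimated value for compound 3 is 700 nM, with an expected range of 150 nM to 3500 nM.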

Compound 3, half-maximal inhibitory concentration: 250 nM
For compound 3 the middle estimate is 2.8-fold (0.45 log units) above the measured one; low and high end bracket the measured number.
By their numbers in this assay, from the lowest: compounds 3 and 1 (each within the scatter of the next); then compound 2.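

In this assay, chloromethyl in place of 2-methylprop-1-en-1-yl on a carbonyl carbon gives a 1.2-fold lower number from compound 1 to compound 3 (0.06 log units; within the scatter) and so leaves the read-out unchanged within the scatter. The earlier compounds shown here could not show that this place accepts a group with 2 heavy atoms instead of 4 and no double bond, with no measurable loss. No measurement offered here explains this match. Still open, from the compounds shown here alone, is whether a plain methyl, an aminomethyl group or a longer carbon chain on the same carbonyl carbon would give a similar number.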